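Swapping hydroxy for amino on compound 3

The compounds below may be only part of what the source reports. "The series", "measured", "known", "first", "only" and "open" are said of these compounds alone.

Values in a functional assay on HCT-116 cells (Homo sapiens) for antiproliferative activity, read by MTT assay, with a stated time of 48 h (a higher number here means a weaker inhibitor, a lower number a stronger inhibitor), are as follows.

- Compound 1 `COc1ccc(-c2cncc3[nH]c(=O)n(Cc4cc(OC)c(OC)c(OC)c4)c23)cc1O` gives > 20000 nM as a limit
- Compound 2 `COc1ccc(-c2nc3cnccc3n2-c2cc(OC)c(OC)c(OC)c2)cc1O` gives > 20000 nM as a limit
- Compound 3 `COc1ccc(-c2cc3c(cn2)[nH]c(=O)n3-c2cc(OC)c(OC)c(OC)c2)cc1O` gives 340 nM as a measured number

For the measured compounds named here, of the three, compound 3 alone returns an actual number, so it is the only compound here with a measured potency in this assay. Compound 1 and compound 2 stop at a limit, (the limit of > 20000 nM in this assay, at which 2 of the 3 values shown sit), and offer no number to compare.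

Compound 4 `COc1ccc(-c2cc3c(cn2)[nH]c(=O)n3-c2cc(OC)c(OC)c(OC)c2)cc1N` keeps the core of compound 3 and changes one group (amino in place of hydroxy on an aromatic carbon). The exchange sits ortho to a methoxy group and meta to a large group, so that 3-hydroxy-4-methoxyphenyl becomes 3-amino-4-methoxyphenyl. Going by the values given here, no measured step covers this exchange, so the expectation starts from compound 3 at 340 nM and foresees no shift beyond the scatter in either direction. The expected change is a 1.1-fold lower number from compound 3 to compound 4 (0.03 log units; within the scatter) in this assay. For compound 4 the estimated value is 320 nM, with an expected range from 90 nM to 1500 nM.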

Compound 4, half-maximal inhibitory concentration: 820 nM
Compound 4: middle estimate off by 2.6-fold (0.41 log units), on the low side; low and high end bracket the measured number.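

In this assay, for the compounds shown here, the change from 3-hydroxy-4-methoxyphenyl to 3-amino-4-methoxyphenyl gives a 2.4-fold higher number from compound 3 to compound 4 (0.38 log units; beyond the scatter), the first measured step at this position, and it shows that the position responds to this exchange, if only modestly. The hydroxy is also not needed for a measurable effect, since compound 4 still returns an actual number, 820 nM. Nothing shown accounts for the step, and the two groups are alike in their printed counts of hydrogen-bond donors and acceptors.

As far as these compounds go, how a fluorine, a methyl group or a plain hydrogen at this place would compare with hydroxy and amino remains open, as does the effect of an acetamide built on the amino group. From the compounds shown here alone, the step also rests on a single pair, so whether it would carry over to another core is unknown.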